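The source may report more compounds than this note shows. Statements on the series, on what has been measured and on what is new or still open speak of the compounds shown alone.

Compound 3 `N#Cc1ccc(Cn2c(=O)n(C3OC(CO)[C@@H](O)[C@H]3O)c3nc(N)nc(O)c32)cc1` reaches 50% in a functional assay on the whole organism (B cells) with Mus musculus as the target (on this read-out lower numbers stand for smaller maximal responses and higher numbers for larger maximal responses), the second highest of the three numbers recorded. Compound 1 `CN(C)CCCn1c(=O)n(C2OC(CO)[C@@H](O)[C@H]2O)c2nc(N)nc(O)c21` reaches 83%, and compound 2 `Nc1nc(O)c2c(n1)n(C1OC(CO)[C@@H](O)[C@H]1O)c(=O)n2Cc1ccc(Cl)cc1` reaches 15%. Compound 4 `NC(=O)Cn1c(=O)n(C2OC(CO)[C@@H](O)[C@H]2O)c2nc(N)nc(O)c21` comes from compound 3 by one change: carbamoyl in place of 4-cyanophenyl on a saturated chain carbon bound to an aromatic nitrogen.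

For the measured compounds named here, two measured steps bear on this. Going from the ring-free chain of compound 1 to an aromatic group gave a number 68 percentage points lower from compound 1 to compound 2 (beyond the scatter) and a number 33 percentage points lower from compound 1 to compound 3 (beyond the scatter); between the two aromatic groups, a number 35 percentage points higher from compound 2 to compound 3 (beyond the scatter). Compound 4 again carries a group without a ring, so a step back toward compound 1 is expected: a number 20 percentage points higher from compound 3 to compound 4 (beyond the scatter). Compound 4 is therefore estimated at 70%, within 45% to 90%.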

Compound 4, largest response reached (reported as maximal response), in percent of the reference or control that the assay uses: 32%
Compound 4: the middle estimate sits 38 percentage points above what was measured; measured number below the stated range.
By their numbers in this assay, from the lowest: compound 2; then compound 4; then compound 3; then compound 1.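

In this assay losing the ring does not by itself restore the response, as the carbamoyl group falls well short of the 2-(dimethylamino)ethyl chain (a number 51 percentage points lower from compound 1 to compound 4 (beyond the scatter)). Its number instead lies among those of the two aromatic groups (a number 18 percentage points lower from compound 3 to compound 4 (beyond the scatter); a number 17 percentage points higher from compound 2 to compound 4 (beyond the scatter)). At this place a ring-free group can therefore also give a low response, and no measured data here account for these steps.

From the compounds shown here alone, whether the high number of compound 1 depends on its dimethylamino group or on its chain remains open. A primary amine, a carboxylic acid or a longer chain without nitrogen at this place could help separate the two.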